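Replacing the acyl group with ethyl: working notes

The compounds below may be only part of what the source reports. "The series", "measured", "known", "first", "only" and "open" are said of these compounds alone.

Three compounds on the shared core differ in the group on a carbonyl carbon. In a functional assay on HT-29 cells (Homo sapiens) for cytotoxicity, read by MTT assay (on this read-out higher numbers stand for weaker inhibition and lower numbers for stronger inhibition), compound 1 `CC(=O)O[C@@H]1OC(=O)[C@](C)(C(C)=O)[C@@H]1C` gives 5000 nM, compound 2 `CC(=O)[C@@]1(C)C(=O)O[C@@H](OC(=O)C(C)(C)C)[C@H]1C` gives 2000 nM and compound 3 `CC(=O)[C@@]1(C)C(=O)O[C@@H](OC(=O)c2ccccc2)[C@H]1C` gives 1000 nM. Compound 2 stands clear of only one of the other two, as the steps show: a 2.5-fold lower number from compound 1 to compound 2 (0.40 log units; beyond the scatter), but a 2.0-fold lower number from compound 2 to compound 3 (0.30 log units; within the scatter).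

Compound 4 `CCO[C@@H]1OC(=O)[C@](C)(C(C)=O)[C@@H]1C` has not been measured. Its change from compound 2 is ethyl in place of (tert-butyl)carbonyl on an oxygen on a saturated carbon. For the measured compounds named here, no measured step covers this change, since all three measured compounds keep the carbonyl and the data show nothing about its removal. The closest guides are the steps at that carbonyl carbon, which stay modest, the largest being a 5.0-fold lower number from compound 1 to compound 3 (0.70 log units; beyond the scatter). Compound 1, with the small methyl group, sets the high end at 5000 nM, so a modest step towards a higher number is expected, with low confidence in its direction. The expected step is a 3.5-fold higher number from compound 2 to compound 4 (0.54 log units; beyond the scatter). In this assay the estimate for compound 4 is 7000 nM, expected to fall within 2500 nM to 25000 nM.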

Compound 4, half-maximal inhibitory concentration: > 50000 nM
Compound 4 was reported as a limit; the forecaster's own chance of this, stated with the estimate: 20%; middle value at least 7.1-fold (0.85 log units) away from the limit.
By their numbers in this assay, from the lowest: compounds 3 and 2 (each within the scatter of the next); then compound 1. At a limit, above all of these: compound 4.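

In this assay, compound 4 is reported as a limit and not as a number: the limit of > 50000 nM in this assay, at which 1 of the 4 values shown sits.

Taking out the whole acyl group and putting ethyl on the oxygen on a saturated carbon gives an at least 25-fold higher number from compound 2 to compound 4 (1.39 log units; beyond the scatter), and the same exchange with acetyl as the leaving group gives an at least 10-fold higher number from compound 1 to compound 4 (1.00 log units; beyond the scatter). These steps show that this oxygen is far less tolerant of losing the acyl group than the carbonyl carbon is of changing its substituent, where methyl, tert-butyl and phenyl all keep the numbers within a modest range. The activity seen so far therefore goes with an acyl group on this oxygen, and ethyl is the one non-acyl group shown there.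

The compounds shown leave open whether the carbonyl itself is what counts or whether ethyl is simply a poor replacement, and a free hydroxyl, an amine or a longer chain on this carbon would help separate the two. Going by these compounds, as both new steps end at a limit, their full size also remains open.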